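Shared core with varied acid-bearing substituents: no measurable activation yet

A few compounds are considered here, and "the series" means these few. Any claim that something is new, unique, unknown or untested is made for them only; others in the source may bear on it.

Working notes on the series around compound 1 `O=C(O)C12CC(CN3CCC[C@H](O[C@H](CO)c4cc(Cl)cc(Cl)c4)[C@@H]3c3ccccc3)(C1)C2`. In an assay on isolated protein for activation of cGMP-dependent protein kinase 1 (Homo sapiens), read by ADP-Glo, with stated times of 30 min and 2 h (on this read-out lower numbers stand for an effect already at smaller amounts and higher numbers for an effect only at larger amounts of compound), compound 1 gives > 200000 nM, which is a limit of the assay and not a number. Compound 3 `CC(=O)NS(=O)(=O)c1ccc(CN2CCC[C@H](O[C@H](CO)c3cc(Cl)cc(Cl)c3)[C@@H]2c2ccccc2)cc1` is measured in this assay at > 200000 nM, again a limit rather than a number. For compound 2 `Cc1cc(C(=O)O)ccc1CN1CCC[C@H](O[C@H](CO)c2cc(Cl)cc(Cl)c2)[C@@H]1c1ccc(F)cc1` this assay records "nd" (no result reported), so no value is available. The position of compound 1 is therefore described only by the limit of > 200000 nM in this assay, at which 2 of the 3 values shown sit; no step between two measured compounds with a single change exists, and nothing in the numbers shown separates compound 1 from compound 3.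

Compound 4 `O=C(O)c1ccc2nc(CN3CCC[C@H](O[C@H](CO)c4cc(Cl)cc(Cl)c4)[C@@H]3c3ccccc3)[nH]c2c1` carries the change (a group of 12 heavy atoms (8 carbon, 2 nitrogen, 2 oxygen; one five-membered aromatic ring with 2 hetero atoms, one six-membered aromatic ring of carbon only) in place of a group of 8 heavy atoms (6 carbon, 2 oxygen; 2 four-membered non-aromatic rings of carbon only), on a saturated chain carbon bound to an amine nitrogen in a ring). The group with two four-membered non-aromatic rings leaves, and the group with one five-membered aromatic ring with 2 hetero atoms and one six-membered aromatic ring of carbon only enters, on a saturated chain carbon bound to an amine nitrogen in a ring.

With both measured neighbours sitting at the limit, the expected step from compound 1 to compound 4 in this assay is a number no higher from compound 1 to compound 4 (the limit leaves the size open), no clear direction beyond the scatter. For compound 4 the estimate in this assay is 200000 nM, with a range from 50000 nM to 600000 nM, and a limit rather than a number is the most likely report.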

Compound 4, half-maximal effective concentration: 43000 nM
Beside the measured number, compound 4's estimate is 4.7-fold (0.67 log units) above it; measured number below the stated range.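

On the saturated chain carbon bound to an amine nitrogen in a ring, the group with one five-membered aromatic ring with 2 hetero atoms and one six-membered aromatic ring of carbon only brings the first read-out in this assay that is a number and not a limit, with an at least 4.6-fold lower number from compound 1 to compound 4 (0.66 log units; beyond the scatter). This place therefore responds to the group it carries, which the earlier compounds could not show, and compound 4 stands alone among the compounds shown in giving a number: the limit of > 200000 nM in this assay, at which 2 of the 4 values shown sit. The true size of the step stays unknown, as its starting point is a limit and not a number.

The two aromatic rings enter together, so the compounds shown do not tell whether the five-membered ring with its 2 hetero atoms, the six-membered ring of carbon only, or only their combination goes with the lower number. Also open, as far as these compounds go, is how the read-out would respond to a tetrazole or an amine in place of the carboxylic acid, or to a longer chain at the same place.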